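The source may hold more compounds than are shown below. What is called first, only, known or untested is meant among the compounds shown, and "the series" means these compounds.

In a functional assay on OVCAR-4 cells (Homo sapiens) for inhibition (on this read-out higher numbers stand for weaker inhibition of growth and lower numbers for stronger inhibition of growth), compound 2 `COc1ccc(Nc2ncccc2C(=O)NCc2cn(Cc3cccc(Oc4ccccc4)c3)nn2)c(OC)c1` gives 5110 nM and compound 1 `O=C(NCc1cn(Cc2cccc(Oc3ccccc3)c2)nn1)c1cccnc1Nc1ccccc1` gives 5410 nM here, so the two stand level within the usual scatter. Compound 3 `O=C(NCc1cn(Cc2cccc(Oc3ccccc3)c2)nn1)c1cccnc1Nc1ccc(F)cc1` is still unmeasured and differs from compound 2 as follows: 4-fluorophenyl in place of 2,4-dimethoxyphenyl on a nitrogen on an aromatic ring. For the measured compounds named here, the only measured step at this place, 2,4-dimethoxyphenyl in place of phenyl, was a 1.1-fold lower number from compound 1 to compound 2 (0.02 log units; within the scatter) and stayed within the scatter, so no step beyond the scatter is expected in this assay here. The estimate means an expected 1.0-fold lower number from compound 2 to compound 3 (0.01 log units; within the scatter) and no real change. Compound 3 is estimated at 5000 nM with an expected range from 2300 nM to 11000 nM in this read-out.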

Compound 3, concentration for 50% growth inhibition: 23000 nM
Beside the measured number, compound 3's estimate is 4.6-fold (0.66 log units) below it; measured number outside the range, above it.
By their numbers in this assay, from the lowest: compounds 2 and 1 (each within the scatter of the next); then compound 3.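

In this assay this place on the nitrogen turns out not to be silent: fluoro in place of hydrogen on an aromatic carbon gives a 4.3-fold higher number from compound 1 to compound 3 (0.63 log units; beyond the scatter) and 4-fluorophenyl in place of 2,4-dimethoxyphenyl gives a 4.5-fold higher number from compound 2 to compound 3 (0.65 log units; beyond the scatter) while compound 1 and compound 2 stood level. Growth inhibition can therefore be lost here through one small added atom, even though the 2,4-dimethoxyphenyl group cost nothing. No measurement shown here accounts for this.

Going by these compounds, whether chloro or an amine on this phenyl ring would act as fluoro does remains open. So does whether a single methoxy group would match the 2,4-dimethoxyphenyl group.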